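Swapping the aryl group on a weakly active core

The source may report more compounds than this note shows. Statements on the series, on what has been measured and on what is new or still open speak of the compounds shown alone.

Compound 3 `Cn1c(=O)c(=O)n(C2CCCC2)c2nc(N/N=C/c3cccc(O)c3)ncc21` shows the lowest number of the three measured compounds in a functional assay on PC-3 cells (Homo sapiens) for antiproliferative activity, read by MTT assay (on this read-out higher numbers stand for weaker inhibition and lower numbers for stronger inhibition), giving 36300 nM. Compound 1 `Cn1c(=O)c(=O)n(C2CCCC2)c2nc(N/N=C/c3ccccc3)ncc21` gives 48200 nM in this assay, and compound 2 `Cn1c(=O)c(=O)n(C2CCCC2)c2nc(N/N=C/c3ccc(O)c(F)c3)ncc21` gives 85200 nM. The step of a 1.3-fold lower number from compound 1 to compound 3 (0.12 log units; within the scatter) lies within the scatter, while the step of a 2.3-fold lower number from compound 2 to compound 3 (0.37 log units; beyond the scatter) is modest but beyond it. Compound 4 `Cn1c(=O)c(=O)n(C2CCCC2)c2nc(N/N=C/c3cc([N+](=O)[O-])ccc3Cl)ncc21` carries 2-chloro-5-nitrophenyl in place of 3-hydroxyphenyl on a carbon with a double bond to nitrogen. The measured steps that touch the same aryl group are a 1.8-fold higher number from compound 1 to compound 2 (0.25 log units; within the scatter) and a 2.3-fold lower number from compound 2 to compound 3 (0.37 log units; beyond the scatter), each modest at most, and the hydroxy change a 1.3-fold lower number from compound 1 to compound 3 (0.12 log units; within the scatter) was smaller still. For the measured compounds named here, every change to this aryl group so far has shifted the number only a little, with no compound going against that, so the expected step of a 1.5-fold higher number from compound 3 to compound 4 (0.18 log units; within the scatter) is also small, if anything toward a somewhat higher number. Compound 4 is therefore estimated at 55000 nM in this assay, with a likely range from 22000 nM to 140000 nM.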

Compound 4, half-maximal inhibitory concentration: 9260 nM
Compound 4: the middle estimate sits 5.9-fold (0.77 log units) above what was measured; measured number outside the range, below it.
By their numbers in this assay, from the lowest: compound 4; then compounds 3, 1 and 2 (each within the scatter of the next, the first and the last beyond it).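

In this assay, for the compounds shown here, the aryl group on the carbon with a double bond to nitrogen turns out to matter more than the earlier compounds suggested, as 2-chloro-5-nitrophenyl gives a 3.9-fold lower number from compound 3 to compound 4 (0.59 log units; beyond the scatter), a 5.2-fold lower number from compound 1 to compound 4 (0.72 log units; beyond the scatter) and a 9.2-fold lower number from compound 2 to compound 4 (0.96 log units; beyond the scatter), which makes compound 4 the most potent of the four. Losing the hydroxy is not enough on its own: compound 1 has a plain phenyl with no hydroxy, and its step to compound 4 is still beyond the scatter. Nothing measured here explains the gain.

The compounds shown do not separate the chlorine from the nitro group, so either one alone, or only the two together, could account for the lower number. Going by these compounds, how an amine or a carboxylic acid on this aryl ring would behave also remains open.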